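The source may report more compounds than this note shows. Statements on the series, on what has been measured and on what is new or still open speak of the compounds shown alone.

Of the compounds shown here, three with a shared core have been tested in a functional assay on SH-SY5Y cells (Homo sapiens) for cytotoxicity, read by MTT assay, with a stated time of 72 h; a higher number here means a weaker inhibitor, a lower number a stronger inhibitor: compound 1 (`O=C1c2c[n+]([O-])c3ccccc3c2C(=O)c2c1c1ccccc1n2CCCCN1CCNCC1`) gives 1240 nM, compound 2 (`CN1CCN(CCCn2c3c(c4ccccc42)C(=O)c2c[n+]([O-])c4ccccc4c2C3=O)CC1`) gives 560 nM and compound 3 (`O=C1c2c[n+]([O-])c3ccccc3c2C(=O)c2c1c1ccccc1n2CCN1CCCCC1`) gives 1860 nM. Compound 3 cannot be told apart from compound 1, as a 1.5-fold higher number from compound 1 to compound 3 (0.18 log units; within the scatter) shows, but it clearly has a higher number than compound 2, as a 3.3-fold higher number from compound 2 to compound 3 (0.52 log units; beyond the scatter) shows.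

Compound 4 (`CN1CCN(CCCCCn2c3c(c4ccccc42)C(=O)c2c[n+]([O-])c4ccccc4c2C3=O)CC1`) differs from compound 3 on a saturated chain carbon, two bonds along the chain from an aromatic nitrogen: 3-(4-methylpiperazin-1-yl)propyl in place of piperidin-1-yl on a saturated chain carbon, two bonds along the chain from an aromatic nitrogen. The best guide is compound 2, which also ends in 4-methylpiperazin-1-yl and gives 560 nM. The other step reaching compound 2, a 2.2-fold lower number from compound 1 to compound 2 (0.35 log units; beyond the scatter), is also modest. Going by the values given here, no measured pair changes chain length alone, so the effect of the longer chain in compound 4 remains open, and the range must stay wide. A modest move towards a lower number is therefore expected, an estimated 3.6-fold lower number from compound 3 to compound 4 (0.55 log units; beyond the scatter). The expected value for compound 4 is 520 nM, with an estimated range of 200 nM to 1300 nM.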

Compound 4, half-maximal inhibitory concentration: 830 nM
The estimate for compound 4 lay 1.6-fold (0.20 log units) below the measured number; measured number inside the range.
By their numbers in this assay, from the lowest: compounds 2, 4, 1 and 3 (each within the scatter of the next, the first and the last beyond it).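

In this assay, replacing piperidin-1-yl with 3-(4-methylpiperazin-1-yl)propyl at this place gives a real but modest change (a 2.2-fold lower number from compound 3 to compound 4 (0.35 log units; beyond the scatter)). Going by these compounds alone, the new result also offers the first look at chain length alone: compounds 2 and 4 both end in 4-methylpiperazin-1-yl, and the longer chain leaves no readable difference (a 1.5-fold higher number from compound 2 to compound 4 (0.17 log units; within the scatter)). The step that changes both the chain and the methyl group on the piperazine also stays within the scatter (a 1.5-fold lower number from compound 1 to compound 4 (0.17 log units; within the scatter)), and nothing available explains any of these results.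

Going by these compounds, whether a morpholine ring at the end of the chain would behave like 4-methylpiperazin-1-yl remains open. So does the effect of a chain longer than the one in compound 4, such as a heptyl linker.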